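The source may report more compounds than this note shows. Statements on the series, on what has been measured and on what is new or still open speak of the compounds shown alone.

Measured compounds:
compound 1, `O=C1C(N2CCCCC2)=CC(=O)c2c1nc1n2[C@H]2OC[C@@H](O)[C@H]2OC1`: > 8000 nM
compound 2, `CCOc1ccccc1NC1=CC(=O)c2nc3n(c2C1=O)[C@H]1OC[C@@H](O)[C@H]1OC3`: > 4000 nM

In a functional assay on MCF7 cells (Homo sapiens) for inhibition, read by sulforhodamine B assay (a lower number here means a stronger inhibitor, a higher number a weaker inhibitor), compound 1 gives > 8000 nM, which is a limit of the assay and not a number. Compound 2 in this assay gives > 4000 nM, which is likewise a limit. Compound 1 therefore stands only at a limit on the numbers shown, and the one further value is a limit as well; no step between the measured compounds can be stated. Compound 3, `O=C1C(NCc2ccccc2)=CC(=O)c2c1nc1n2[C@H]2OC[C@@H](O)[C@H]2OC1`, is still to be measured in this assay. It differs from compound 1 by benzylamino in place of piperidin-1-yl on a double-bonded ring carbon. With compound 1 sitting at the limit of > 8000 nM in this assay, at which 1 of the 2 values shown sits, and compound 2 at the limit of > 4000 nM in this assay, at which 1 of the 2 values shown sits, the measured values give no ground for a change beyond the scatter in either direction. The expected step is a number no higher from compound 1 to compound 3 (the limit leaves the size open), of no clear direction. For compound 3 the estimate in this assay is 8000 nM, between 2000 nM and 30000 nM, most likely reported again only as a limit.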

Compound 3, half-maximal inhibitory concentration: > 8000 nM
Compound 3: no number, only a limit; the forecaster's own chance of this, stated with the estimate: 65%; the middle value lies on the limit itself.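

In this assay compound 3 gives > 8000 nM, a limit and not a number. Going by these compounds alone, compound 1 also stands only at a limit, so no step from compound 1 to compound 3 can be read. The compounds shown leave open how piperidin-1-yl and benzylamino compare in this assay.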